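This account rests on a few compounds, and the source may have more. Where it says the series, first, only, none or still open, it means among the compounds named here.

Measured in an ADME assay on HepG2 2.2.15 cells (Homo sapiens) for cytotoxicity; on this read-out higher numbers stand for lower toxicity in this test and lower numbers for higher toxicity in this test:
Compound 1 `CCCC(=O)OCCc1c(-c2ccccc2Cl)c2cc(Cl)ccc2[nH]c1=O` gives 52000 nM
Compound 2 `O=C(O)CCCC(=O)OCCc1c(-c2ccccc2Cl)c2cc(Cl)ccc2[nH]c1=O` gives 110000 nM
Compound 3 `O=C(OCCc1c(-c2ccccc2Cl)c2cc(Cl)ccc2[nH]c1=O)c1cccnc1` gives 170000 nM

Two gaps place compound 3. The smaller one (a 1.5-fold higher number from compound 2 to compound 3 (0.19 log units; within the scatter)) does not separate it from its nearest neighbour, whereas the larger one (a 3.3-fold higher number from compound 1 to compound 3 (0.51 log units; beyond the scatter)) sets it clear of the lowest number.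

In compound 4 `O=C(OCCc1c(-c2ccccc2Cl)c2cc(Cl)ccc2[nH]c1=O)c1ccco1`, furan-2-yl stands in place of pyridin-3-yl on a carbonyl carbon (furan-2-yl in place of pyridin-3-yl on a carbonyl carbon). For the measured compounds named here, no measured step swaps one aromatic ring for another, so the evidence is indirect. Those same two gaps are the closest guide, since each changes the group on this carbonyl carbon. Even replacing a saturated chain with pyridin-3-yl gave only a modest change (a 3.3-fold higher number from compound 1 to compound 3 (0.51 log units; beyond the scatter)), so in this assay no step beyond the scatter is expected here. The expected step is a 1.3-fold lower number from compound 3 to compound 4 (0.12 log units; within the scatter) and remains small. For compound 4 the estimated value is 130000 nM within an expected range from 60000 nM to 260000 nM (an estimate only).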

Compound 4, half-maximal cytotoxic concentration: 98000 nM
Beside the measured number, compound 4's estimate is 1.3-fold (0.12 log units) above it; the range from low to high includes it.
By their numbers in this assay, from the lowest: compounds 1, 4, 2 and 3 (each within the scatter of the next, the first and the last beyond it).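

In this assay, for the compounds shown here, furan-2-yl in place of pyridin-3-yl is the first swap of one aromatic ring for another on this carbonyl carbon, and the step stays within the scatter (a 1.7-fold lower number from compound 3 to compound 4 (0.24 log units; within the scatter)). Compound 4 also cannot be told apart from the compounds carrying 3-carboxypropyl (a 1.1-fold lower number from compound 2 to compound 4 (0.05 log units; within the scatter)) or propyl (a 1.9-fold higher number from compound 1 to compound 4 (0.28 log units; within the scatter)), so it fills the gap between compound 1 and compound 3, which remain separated from each other only when compared directly. Nothing available here explains these numbers.

Open, going by these compounds, is whether a plain phenyl ring, a ring bearing an amine, or a much longer saturated chain on this carbonyl carbon would give a step beyond the scatter. Also open, on these data alone, is what an amide in place of the ester oxygen would do.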